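This account rests on a few compounds, and the source may have more. Where it says the series, first, only, none or still open, it means among the compounds named here.

Measured so far in a functional assay on MCF7 cells (Homo sapiens) for inhibition, read by MTT assay; a higher number here means a weaker inhibitor, a lower number a stronger inhibitor:

Compound 1 `COc1cc2ncnc(Nc3ccc(NC(=O)c4ccc(F)cc4)cc3)c2cc1OC` gives 27000 nM
Compound 2 `COc1cc2ncnc(Nc3ccc(NC(=O)c4ccc(Br)cc4)cc3)c2cc1OC` gives 43000 nM
Compound 3 `COc1cc2ncnc(Nc3ccc(NC(=O)c4ccccc4I)cc3)c2cc1OC` gives 37000 nM

Compound 3 stands with the other two and is separated from neither. The steps that reach it are a 1.4-fold higher number from compound 1 to compound 3 (0.14 log units; within the scatter) and a 1.2-fold lower number from compound 2 to compound 3 (0.07 log units; within the scatter) when the group on the carbonyl carbon is exchanged. The remaining step, bromo in place of fluoro on an aromatic carbon, is a 1.6-fold higher number from compound 1 to compound 2 (0.20 log units; within the scatter) and completes the set.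

The next compound is compound 4 `COc1cc2ncnc(Nc3ccc(NC(=O)c4c(F)cccc4F)cc3)c2cc1OC`. Its difference from compound 3 is 2,6-difluorophenyl in place of 2-iodophenyl on a carbonyl carbon and amounts to 2,6-difluorophenyl in place of 2-iodophenyl on a carbonyl carbon. Going by the values given here, no measured compound carries the 2,6-difluorophenyl group, so the three steps above are only indirect guides. They do bear on it, as each exchanges the group at this same place and none leaves the scatter in this assay for these three compounds. No step beyond the scatter is therefore expected, and no direction can be argued with any weight. The expected step is a 1.1-fold lower number from compound 3 to compound 4 (0.05 log units; within the scatter) and is no more than a small estimated shift. For compound 4 the estimated value is 33000 nM with an expected range from 17000 nM to 62000 nM in this series.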

Compound 4, half-maximal inhibitory concentration: 24000 nM
Beside the measured number, compound 4's estimate is 1.4-fold (0.14 log units) above it; low and high end bracket the measured number.
By their numbers in this assay, from the lowest: compounds 4, 1, 3 and 2 (each within the scatter of the next).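

In this assay, the set now includes a phenyl group with two halogen atoms, 2,6-difluorophenyl, and the steps reaching it all stay inside the scatter: a 1.5-fold lower number from compound 3 to compound 4 (0.19 log units; within the scatter) against 2-iodophenyl, a 1.8-fold lower number from compound 2 to compound 4 (0.25 log units; within the scatter) against 4-bromophenyl and a 1.1-fold lower number from compound 1 to compound 4 (0.05 log units; within the scatter) against 4-fluorophenyl. The earlier compounds shown here covered only single halogen exchanges on this phenyl group, whereas these steps show that a second halogen, with iodo or bromo replaced by fluoro, also fails to separate any compound from the others, so the four compounds remain one group at this position. No measurement shown here offers an explanation for this flat result.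

On these data alone, all four groups on the carbonyl carbon are halogenated phenyl groups, so it remains open whether any other group at this place would give a step beyond the scatter. An aminomethyl or carboxylic acid substituent on the phenyl group, or a longer alkyl chain in place of the phenyl group, would test this, and the values shown give no guide to the direction of either change.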